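Replacing the aromatic ring of compound 2

The compounds below may be only part of what the source reports. "The series", "measured", "known", "first", "only" and "open" are said of these compounds alone.

Among the measured compounds shown here, in a functional assay on the whole organism (stomach) for inhibition, with Rattus norvegicus as the target (a higher number here means that more compound is needed for the effect, a lower number that less compound is needed), compound 2, `O=C(O)CCC/C=C1\CC2C[C@@H](O)[C@H](/C=C/[C@@H](O)C3COc4ccccc4O3)C2C1`, gives 0.0045 mg/kg, the only actual number so far. Compound 1, `O=C(O)CCC/C=C1\CC2C[C@@H](O)[C@H](/C=C/[C@@H](O)c3ccc4c(c3)OCCO4)C2C1`, is reported only as a limit, > 0.3 mg/kg. The two compounds carry the same 2,3-dihydro-1,4-benzodioxin group, attached through different positions, and the step between them is an at least 66-fold lower number from compound 1 to compound 2 (1.82 log units; beyond the scatter).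

Compound 3, `O=C(O)CCC/C=C1\CC2C[C@@H](O)[C@H](/C=C/[C@@H](O)C3COC4CCCCC4O3)C2C1`, has not yet been measured. It keeps the shared core and changes only the group on the saturated chain carbon: a group of 10 heavy atoms (8 carbon, 2 oxygen; one six-membered non-aromatic ring of carbon only, one six-membered non-aromatic ring with 2 hetero atoms) in place of a group of 10 heavy atoms (8 carbon, 2 oxygen; one six-membered non-aromatic ring with 2 hetero atoms, one six-membered aromatic ring of carbon only), on a saturated chain carbon bound to a double-bonded chain carbon and an oxygen on a saturated carbon. The six-membered aromatic ring of carbon only thus gives way to a six-membered non-aromatic ring of carbon only, while the ring with 2 hetero atoms stays.

For the measured compounds named here, no measured step makes this exact change. Going by the values given here, the single step available, an at least 66-fold lower number from compound 1 to compound 2 (1.82 log units; beyond the scatter), shows only that this assay can respond strongly to a change in this group, so a real shift is plausible. A smaller effect is expected here, with a somewhat higher number, and the expected size is a 4.4-fold higher number from compound 2 to compound 3 (0.65 log units; beyond the scatter). For compound 3 the estimated dose is 0.02 mg/kg, with an expected range of 0.003 mg/kg to 0.15 mg/kg.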

Compound 3, dose for half-maximal effect: 0.256 mg/kg
The estimate for compound 3 lay 13-fold (1.11 log units) below the measured number; the measured number lies above the stated range.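

Compound 1 and compound 2 differ in how the 2,3-dihydro-1,4-benzodioxin group is attached, whereas this step keeps that attachment and the ring with 2 hetero atoms and alters only the aromatic ring. In this assay, that single change gives a 57-fold higher number from compound 2 to compound 3 (1.76 log units; beyond the scatter), so the response at this saturated chain carbon depends on the ring type as well as on the attachment, even though the two groups have the same heavy-atom count and net charge. The remaining step is an at least 1.1-fold lower number from compound 1 to compound 3 (0.06 log units; that floor lies within the scatter), and that floor lies within the scatter. It cannot be read as a difference, because compound 1 is known only as a limit: the limit of > 0.3 mg/kg in this assay, at which 1 of the 3 values shown sits.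

The compounds shown leave open whether the low dose of compound 2 requires an aromatic ring of carbon only, as a pyridine or thiophene ring in its place would test. They also leave open whether the ring with 2 hetero atoms is needed at all, which a plain phenyl group on the same chain carbon would help to answer.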